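The source may hold more compounds than are shown below. What is called first, only, known or untested is meant among the compounds shown, and "the series" means these compounds.

Measured compounds in a functional assay on MCF7 cells (Homo sapiens) for antiproliferative activity; a lower number here means a stronger inhibitor, a higher number a weaker inhibitor:
compound 1 `CC(C)=CCc1cc(C(=O)Nc2cc3ccc(OCCCNCC(C)C)c(C)c3oc2=O)ccc1O` gives 1320 nM
compound 2 `CC(C)=CCc1cc(C(=O)Nc2cc3ccc(OCCCNCC(=O)O)c(C)c3oc2=O)ccc1O` gives 18100 nM
compound 3 `CC(C)=CCc1cc(C(=O)Nc2cc3ccc(OCCCN(C)Cc4ccccc4)c(C)c3oc2=O)ccc1O` gives 11500 nM

Compound 1 gives the lowest number of the three; compound 3 comes nearest, with an 8.7-fold higher number from compound 1 to compound 3 (0.94 log units; beyond the scatter), and compound 2 lies furthest, with a 14-fold higher number from compound 1 to compound 2 (1.14 log units; beyond the scatter). Compound 2 and compound 3 differ by a 1.6-fold lower number from compound 2 to compound 3 (0.20 log units; within the scatter).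

Compound 4 `CC(C)=CCc1cc(C(=O)Nc2cc3ccc(OCCCN[C@@H]4C[C@H]5CC[C@@H]4C5)c(C)c3oc2=O)ccc1O` is not yet measured. Relative to compound 1 the change is a group of 7 heavy atoms (7 carbon; 2 five-membered non-aromatic rings of carbon only) in place of a group of 4 heavy atoms (4 carbon; no ring), on an amine nitrogen.

Both measured steps away from compound 1 alter the substituent on the same amine nitrogen, and both weaken inhibition clearly: a 14-fold higher number from compound 1 to compound 2 (1.14 log units; beyond the scatter) and an 8.7-fold higher number from compound 1 to compound 3 (0.94 log units; beyond the scatter). Neither step keeps an all-carbon substituent on a secondary amine as the step to compound 4 does, so they bear on it only loosely; they show that this position is sensitive, without showing how a larger hydrocarbon group fares. A weakening of modest size, or none beyond the scatter, is therefore expected in this assay .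

The step from compound 1 to compound 4 is estimated as a 2.0-fold higher number from compound 1 to compound 4 (0.29 log units; within the scatter). Compound 4 is expected to give 2600 nM, with a range of 900 nM to 7500 nM.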

Compound 4, half-maximal inhibitory concentration: 1030 nM
Compound 4: middle estimate off by 2.5-fold (0.40 log units), on the high side; measured number inside the range.
By their numbers in this assay, from the lowest: compounds 4 and 1 (each within the scatter of the next); then compounds 3 and 2 (each within the scatter of the next).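

In this assay, the group of 7 carbon atoms with 2 five-membered non-aromatic rings replaces isobutyl on the amine nitrogen with a 1.3-fold lower number from compound 1 to compound 4 (0.11 log units; within the scatter), so this position tolerates this much larger all-carbon group in compound 4. The same group separates clearly from the substituents of the two weaker compounds, with an 11-fold lower number from compound 3 to compound 4 (1.05 log units; beyond the scatter) and an 18-fold lower number from compound 2 to compound 4 (1.24 log units; beyond the scatter), so added size alone does not account for the higher numbers of compound 2 and compound 3. No supporting data explain why these substituents differ.

Going by these compounds, how a cyclohexyl or dimethylamino group on this nitrogen would compare remains open. Also open is whether the 3 defined stereocentres of the entering group matter, as its mirror-image form is not among the compounds shown.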